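Replacing benzylselanyl with methylsulfanyl on a diacylated core

The compounds below may be only part of what the source reports. "The series", "measured", "known", "first", "only" and "open" are said of these compounds alone.

Measured compounds:
compound 1 `C[Se]/C(=N\C(=O)c1cccs1)NC(=O)c1cccs1`, 630 nM
compound 2 `O=C(/N=C(/NC(=O)c1ccno1)[Se]Cc1ccccc1)c1ccno1`, 9120 nM
compound 3 `O=C(/N=C(/NC(=O)c1cccs1)[Se]Cc1ccccc1)c1cccs1`, 34700 nM

In a functional assay on HepG2 cells (Homo sapiens) for cytotoxicity, read by MTT assay, with a stated time of 72 h (on this read-out higher numbers stand for weaker inhibition of growth and lower numbers for stronger inhibition of growth), compound 3 stands highest of the three numbers; compound 2 lies nearest to it and compound 1 lies furthest away. Compound 4 `CS/C(=N\C(=O)c1cccs1)NC(=O)c1cccs1` differs from compound 3 by a group of 2 heavy atoms (1 carbon, 1 sulfur; no ring) in place of a group of 8 heavy atoms (7 carbon, 1 selenium; one six-membered aromatic ring of carbon only), on a carbon with a double bond to nitrogen. Going by the values given here, one measured step bears on this change: a 55-fold higher number from compound 1 to compound 3 (1.74 log units; beyond the scatter), which is large. Among the compounds with values here, the change from compound 3 to compound 4 reverses that benzyl substitution but also swaps selenium for sulfur, for which no measured pair exists, so the expected step is judged large and downward. Compound 4 is therefore estimated at 1500 nM, within 300 nM to 8000 nM, a step of a 23-fold lower number from compound 3 to compound 4 (1.36 log units; beyond the scatter) expected from compound 3.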

Compound 4, concentration for 50% growth inhibition: > 100000 nM
Compound 4 gave a limit, no number; the forecaster's own chance of this, stated with the estimate: 5%; middle value at least 66-fold (1.82 log units) away from the limit.
By their numbers in this assay, from the lowest: compound 1; then compound 2; then compound 3. At a limit, above all of these: compound 4.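

Compound 4 sits at a limit and not at a number: the limit of > 100000 nM in this assay, at which 1 of the 4 values shown sits. With the methyl kept on the carbon with a double bond to nitrogen, sulfur in place of selenium gives an at least 150-fold higher number from compound 1 to compound 4 (2.20 log units; beyond the scatter), the first view of that atom exchange alone. The short methylsulfanyl group therefore does not bring the low number that the short selenium group brought, and the exchange for the benzyl-bearing selenium group gives an at least 2.8-fold higher number from compound 3 to compound 4 (0.45 log units; beyond the scatter). Going by these compounds, what a benzylsulfanyl group or a longer chain on selenium would give on the shared core stays open. On these data alone, how far compound 4 lies past its limit also stays open.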